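This account rests on a few compounds, and the source may have more. Where it says the series, first, only, none or still open, it means among the compounds named here.

Compound 1 `O=C(Nc1cccc(C(F)(F)F)c1)N[C@H]1CC[C@H](O)CC1` sits at a limit of a functional assay on CRL2813 cells (Homo sapiens) for cytotoxicity, read by sulforhodamine B assay, with a stated time of 5 days (a lower number here means a stronger inhibitor, a higher number a weaker inhibitor), giving > 20000 nM. Compound 2 `O=C(Nc1cccc(F)c1)N[C@H]1CC[C@H](Oc2ccc(F)cc2)CC1` gives 8300 nM in this assay. Compound 3 `CSc1ccc(NC(=O)N[C@H]2CC[C@H](Oc3ccc(F)cc3)CC2)cc1` again reaches only a limit in this assay, > 20000 nM. Within the data shown here, the one measured step, an at least 2.4-fold higher number from compound 2 to compound 3 (0.38 log units; beyond the scatter), is thus a loss that ends at the limit of > 20000 nM in this assay, at which 2 of the 3 values shown sit, so compound 3 stands among the weakest values shown, though no number fixes how far. Compound 4 `O=C(Nc1ccccc1I)N[C@H]1CC[C@H](Oc2ccc(F)cc2)CC1` differs from compound 3 by 2-iodophenyl in place of 4-(methylsulfanyl)phenyl on an amide-type nitrogen. Among the measured compounds shown here, no measured step covers this exchange; the step of an at least 2.4-fold higher number from compound 2 to compound 3 (0.38 log units; beyond the scatter) shows only that a halophenyl gave a number where the methylsulfanyl group did not, so a return toward the value of compound 2 is expected. Compound 4 is estimated at 10000 nM in this assay, between 3000 nM and 20000 nM. The expected step of an at least 2.0-fold lower number from compound 3 to compound 4 (0.30 log units; that floor lies within the scatter) is therefore a modest gain, uncertain in size.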

Compound 4, half-maximal inhibitory concentration: > 20000 nM
Compound 4: no number, only a limit; the forecaster's own chance of this, stated with the estimate: 40%; middle value at least 2.0-fold (0.30 log units) away from the limit.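

In this assay compound 4 reaches only a limit, not a number: the limit of > 20000 nM in this assay, at which 3 of the 4 values shown sit.

Among these compounds, the step, an at least 2.4-fold higher number from compound 2 to compound 4 (0.38 log units; beyond the scatter), shows that a halophenyl on the amide-type nitrogen does not by itself give a readable value, and 3-fluorophenyl remains the only group on that nitrogen here that does. The step between compound 3 and compound 4 cannot be read, as both are limits.

From the compounds shown here alone, whether the loss follows the iodine or its place on the ring stays open, as does what a chlorophenyl or an aminophenyl group on that nitrogen would give.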